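Benzofuran replacing methoxyphenyl on the amide of compound 1

The source may report more compounds than this note shows. Statements on the series, on what has been measured and on what is new or still open speak of the compounds shown alone.

Compound 1 `COc1ccccc1C(=O)Nc1c[nH]nc1C(=O)N[C@H]1CC[C@H](OC)CC1` gives the lowest number of the three measured compounds in an ADME assay on MRC5 cells (Homo sapiens) for inhibition, with a stated time of 72 h (on this read-out lower numbers stand for an effect already at smaller amounts and higher numbers for an effect only at larger amounts of compound), at 1500 nM. Compound 2 `CO[C@H]1CC[C@H](NC(=O)c2n[nH]cc2NC(=O)c2ccccc2C(F)(F)F)CC1` gives 3300 nM in this assay, and compound 3 `COc1cccc(OC)c1C(=O)Nc1c[nH]nc1C(=O)N[C@H]1CC[C@H](OC)CC1` gives 31000 nM. The two steps away from compound 1 both raise the number: a 2.2-fold higher number from compound 1 to compound 2 (0.34 log units; beyond the scatter), and a 21-fold higher number from compound 1 to compound 3 (1.32 log units; beyond the scatter).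

Compound 4 `CO[C@H]1CC[C@H](NC(=O)c2n[nH]cc2NC(=O)c2cc3ccccc3o2)CC1` is not yet measured. It differs from compound 1 by 1-benzofuran-2-yl in place of 2-methoxyphenyl on a carbonyl carbon. Neither measured step matches this change, since both keep a phenyl ring and alter its substituents, whereas here the whole aromatic group is exchanged. Going by the values given here, what the two steps do show is that every change tried at this position so far has made the number in this assay higher, once modestly and once by a large amount. A step in the same direction is therefore expected for compound 4, of a size between those two, though with wide uncertainty. Compound 4 is estimated at 4500 nM in this assay, within a range of 1200 nM to 18000 nM, which corresponds to an expected step of a 3.0-fold higher number from compound 1 to compound 4 (0.48 log units; beyond the scatter).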

Compound 4, half-maximal effective concentration: 800 nM
Estimate against measurement, compound 4: 5.6-fold (0.75 log units) above, outside the stated range (below it).
By their numbers in this assay, from the lowest: compounds 4 and 1 (each within the scatter of the next); then compound 2; then compound 3.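

In this assay the exchange of 2-methoxyphenyl for 1-benzofuran-2-yl on a carbonyl carbon gives a 1.9-fold lower number from compound 1 to compound 4 (0.27 log units; within the scatter) and so leaves compound 4 on a par with compound 1. Compound 2 and compound 3 had both kept the phenyl ring and moved beyond the scatter from compound 1, whereas compound 4 shows that the 2-methoxyphenyl group can be replaced as a whole, by a group with a five-membered and a six-membered aromatic ring, without such a shift. Nothing given here accounts for this difference between the three changes.

Still open, as far as these compounds go, is whether an indolyl or a benzothiophenyl group on this carbonyl carbon would behave like 1-benzofuran-2-yl. Also open, from the compounds shown here alone, is what an amine or a carboxylic acid on the 1-benzofuran-2-yl group would do to the number.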